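Fluorines in place of bromine and methyl on the anilide

A few compounds are considered here, and "the series" means these few. Any claim that something is new, unique, unknown or untested is made for them only; others in the source may bear on it.

Compound 1 `O=C(COc1ccc(/C=C2\SC(=O)NC2=O)cc1)Nc1cccc([N+](=O)[O-])c1` — this assay: > 100000 nM
Compound 2 `O=C(COc1ccc(/C=C2\SC(=O)NC2=O)cc1)Nc1ccc(Br)cc1` — this assay: 32100 nM
Compound 3 `Cc1cc(Br)ccc1NC(=O)COc1ccc(/C=C2\SC(=O)NC2=O)cc1` — this assay: > 100000 nM

Three anilides of the shared core have been measured in a functional assay on KB cells (Homo sapiens) for inhibition; a lower number here means a stronger inhibitor of growth, a higher number a weaker inhibitor of growth. Compound 2 gives 32100 nM. Compound 1 reaches only the limit of the assay, > 100000 nM, and no number. Compound 3 likewise sits at a limit, > 100000 nM, so its standing is known only as a bound; it shares that bound with compound 1 (the limit of > 100000 nM in this assay, at which 2 of the 3 values shown sit).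

The step from compound 2 to compound 3 was an at least 3.1-fold higher number from compound 2 to compound 3 (0.49 log units; beyond the scatter). The step from compound 1 to compound 2 was an at least 3.1-fold lower number from compound 1 to compound 2 (0.49 log units; beyond the scatter), while the step from compound 1 to compound 3 was a step that the two limits leave unreadable from compound 1 to compound 3.

Compound 4 `O=C(COc1ccc(/C=C2\SC(=O)NC2=O)cc1)Nc1ccc(F)cc1F` carries the change (2,4-difluorophenyl in place of 4-bromo-2-methylphenyl on an amide-type nitrogen). Among the measured compounds shown here, removing the methyl undoes the change that cost compound 2 its measurable number, so compound 4 is expected to move back toward a readable value, though the fluorines have no counterpart among the three measured compounds. Compound 4 is expected to give about 60000 nM, between 20000 nM and 150000 nM, an expected step of an at least 1.6-fold lower number from compound 3 to compound 4 (0.22 log units; that floor lies within the scatter).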

Compound 4, concentration for 50% growth inhibition: > 100000 nM
Compound 4 gave a limit, no number (the forecaster's own chance of this, stated with the estimate: 45%); middle value at least 1.6-fold (0.22 log units) from the limit.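

In this assay compound 4 reaches only a limit, > 100000 nM, and no number. The 2,4-difluorophenyl group in place of 4-bromophenyl on the amide-type nitrogen gives an at least 3.1-fold higher number from compound 2 to compound 4 (0.49 log units; beyond the scatter), which shows that an anilide without the methyl of compound 3 can still fail to give a number, and compound 2 remains the only anilide with a measured value. The steps from compound 1 and compound 3 to compound 4 cannot be read, and the limit now holds most of the series: the limit of > 100000 nM in this assay, at which 3 of the 4 values shown sit.

The compounds shown do not separate the loss of the bromine from the gain of either fluorine. From the compounds shown here alone, whether a chlorine, an amine or a carboxylic acid on the anilide ring would give a number in this assay also stays open.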